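The source may hold more compounds than are shown below. What is called first, only, known or untested is meant among the compounds shown, and "the series" means these compounds.

Compound 1 `C#CC(=O)N(Cc1ccc(OC)c(O)c1)c1cc(OC)c(OC)c(OC)c1` gives 570 nM in a functional assay on KYSE-450 cells (Homo sapiens) for inhibition, read by MTT assay, with a stated time of 48 h; on this read-out lower numbers stand for stronger inhibition and higher numbers for weaker inhibition.
Compound 2 `COc1ccc(CN(C(C)=O)c2cc(OC)c(OC)c(OC)c2)cc1O` gives 160 nM.
Compound 3 `C/C=C/C(=O)N(Cc1ccc(OC)cc1)c1cc(OC)c(OC)c(OC)c1` gives 420 nM.

Among these three numbers compound 3 stands second highest. Its nearest neighbour is compound 1, whose number lies within the scatter of that of compound 3, so nothing separates the two. Compound 2 lies furthest away, with a number beyond the scatter below that of compound 3. For the measured compounds named here, the one step measured so far, a 3.6-fold lower number from compound 1 to compound 2 (0.55 log units; beyond the scatter), concerns the group on the carbonyl carbon and says nothing about the aromatic ring.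

Compound 4 `C/C=C/C(=O)N(Cc1ccc(OC)c(O)c1)c1cc(OC)c(OC)c(OC)c1` differs from compound 3 by hydroxy in place of hydrogen on an aromatic carbon. Going by the values given here, no measured pair isolates this change. Compound 1 and compound 3 differ in two places at once, one of them this hydroxy group, and their two values sit within the scatter of each other; that is the only hint the data give, and it points to no effect. The expected step of a 1.1-fold lower number from compound 3 to compound 4 (0.02 log units; within the scatter) is therefore one that stays within the scatter. Compound 4 is estimated at 400 nM, with a range from 150 nM to 1100 nM.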

Compound 4, half-maximal inhibitory concentration: 67 nM
The estimate for compound 4 lay 6.0-fold (0.78 log units) above the measured number; measured number below the stated range.
By their numbers in this assay, from the lowest: compound 4; then compound 2; then compounds 3 and 1 (each within the scatter of the next).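

For the compounds shown here, the change from 4-methoxyphenyl to 3-hydroxy-4-methoxyphenyl gives the first reading of this position on its own: in this assay, hydroxy in place of hydrogen, ortho to a methoxy group, gives a 6.3-fold lower number from compound 3 to compound 4 (0.80 log units; beyond the scatter). With the hydroxy group present throughout, the group on the carbonyl carbon also separates the compounds: prop-1-en-1-yl in place of methyl gives a 2.4-fold lower number from compound 2 to compound 4 (0.38 log units; beyond the scatter), and prop-1-en-1-yl in place of ethynyl gives an 8.5-fold lower number from compound 1 to compound 4 (0.93 log units; beyond the scatter), so prop-1-en-1-yl gives the lowest number of these three groups. No supporting measurement is available to explain either the hydroxy step or the steps at the carbonyl carbon.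

The compounds shown leave open whether the hydroxy step carries over to methyl or ethynyl on the carbonyl carbon, as the only compound without this hydroxy group carries prop-1-en-1-yl. They also leave open what an amine, a fluorine atom or a second methoxy group would give in place of the hydroxy group, and what a longer chain than prop-1-en-1-yl would give on the carbonyl carbon.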